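A few compounds are considered here, and "the series" means these few. Any claim that something is new, unique, unknown or untested is made for them only; others in the source may bear on it.

Working notes on the series.

Compound 1 `CCCCCCCCCCCCNC(=O)c1c[nH]c(-c2ccccc2)n1` and compound 2 `CCCCCCCCCCCCCCNC(=O)c1c[nH]c(-c2ccccc2)n1` share one core; compound 3 `CCCCCCCCCCCCCCCCNC(=O)[C@@H]1CNC(c2ccccc2)=N1` carries a different core, and the difference between the two cores is not broken down here. In a functional assay on B16-F1 cells (Mus musculus) for antiproliferative activity, read by sulforhodamine B assay, with a stated time of 48 h (a higher number here means a weaker inhibitor, a lower number a stronger inhibitor), compound 1 gives 30000 nM and compound 2 gives 38200 nM. The change from compound 1 to compound 2 is ethyl in place of hydrogen on a saturated chain carbon, ten or more bonds along the chain from an amide-type nitrogen and its step is a 1.3-fold higher number from compound 1 to compound 2 (0.10 log units; within the scatter). In this assay compound 3 gives 5700 nM, the lowest of the three numbers, with both other compounds beyond the scatter from it.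

Compound 4 `CCCCCCCCCCCCCCCCCCNC(=O)[C@@H]1CNC(c2ccccc2)=N1` is not yet measured. It differs from compound 3 by ethyl in place of hydrogen on a saturated chain carbon, ten or more bonds along the chain from an amide-type nitrogen, the same change as made from compound 1 to compound 2, at a place described in the same words. The expectation for compound 4 in this assay rests on compound 3 and on the earlier step, because a 1.3-fold higher number from compound 1 to compound 2 (0.10 log units; within the scatter) lay within the scatter. The step from compound 3 to compound 4 is expected to be a 1.2-fold higher number from compound 3 to compound 4 (0.09 log units; within the scatter). Compound 4 is thus estimated at 7000 nM, between 3000 nM and 16000 nM.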

Compound 4, half-maximal inhibitory concentration: 50500 nM
The estimate for compound 4 lay 7.2-fold (0.86 log units) below the measured number; measured number above the stated range.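

In this assay, ethyl in place of hydrogen on a saturated chain carbon, ten or more bonds along the chain from an amide-type nitrogen, does not carry from one core to the other with the same size of step: the same change on two cores in this assay, a 1.3-fold higher number (0.10 log units; within the scatter) from compound 1 to compound 2 and an 8.9-fold higher number (0.95 log units; beyond the scatter) from compound 3 to compound 4, 7.0-fold (0.84 log units) apart, beyond the scatter of two such steps

Among these compounds, on the core of compound 3 the change gives an 8.9-fold higher number from compound 3 to compound 4 (0.95 log units; beyond the scatter), so the small step on the core of compound 1 was no guide to the step here. This does not show that the core alone sets the size of the step, since each core offers a single pair and the two pairs start from chains of different length, which leaves core and chain length unseparated.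

From the compounds shown here alone, it remains open whether the core of compound 1 would show a similar step starting from the chain of compound 3. Also open, going by these compounds, is how a longer chain, or a chain carrying an amine or a carboxylic acid, would behave on either core.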